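This account rests on a few compounds, and the source may have more. Where it says the series, first, only, none or still open, it means among the compounds named here.

The series rests on three measured compounds. Compound 1 `CC(C)(C)OC(=O)N1CCC(Oc2cccc3c2ccn3-c2ccc(S(C)(=O)=O)cc2)CC1` gives 631 nM in a functional assay on CHO-K1 cells for agonist activity at Glucose-dependent insulinotropic receptor (Homo sapiens), read by a luciferase reporter, with a stated time of 5 h; on this read-out lower numbers stand for an effect already at smaller amounts and higher numbers for an effect only at larger amounts of compound. Compound 2 `CC(C)OC(=O)N1CCC(Oc2ncnc3c2CCN3c2ccc(S(C)(=O)=O)cn2)CC1` gives 126 nM in this assay, and compound 3 `CC(C)OC(=O)N1CCC(Oc2ncnc3c2CCN3c2ccc(S(C)(=O)=O)nc2)CC1` gives 251 nM in this assay. Among the measured compounds shown here, the one single-point step among them, a 2.0-fold higher number from compound 2 to compound 3 (0.30 log units; within the scatter), lies within the scatter. Compound 3 thus stands second highest of the three numbers, nearest to compound 2, and furthest from compound 1, whose number is higher by a margin beyond the scatter.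

Compound 4 `CC(C)OC(=O)N1CCC(Oc2ncnc3c2CCN3c2ccc(S(C)(=O)=O)c(F)c2)CC1` differs from compound 3 in one place: 3-fluoro-4-(methylsulfonyl)phenyl in place of 6-(methylsulfonyl)pyridin-3-yl on a nitrogen on an aromatic ring in a ring. For the measured compounds named here, no measured step mirrors this exchange. Going by the values given here, the only step available, a 2.0-fold higher number from compound 2 to compound 3 (0.30 log units; within the scatter), concerns a different exchange at the same place and stayed within the scatter; compound 1 carries a related group on another core with further differences, so its value cannot be tied to that group alone. The step expected is therefore one within the scatter, a 1.0-fold lower number from compound 3 to compound 4 (0.00 log units; within the scatter), in this assay. For compound 4 the estimate is 250 nM, with a range from 80 nM to 800 nM.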

Compound 4, half-maximal effective concentration: 158 nM
For compound 4 the middle estimate is 1.6-fold (0.20 log units) above the measured one; the measured number falls inside the stated range.
By their numbers in this assay, from the lowest: compounds 2, 4 and 3 (each within the scatter of the next); then compound 1.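

Among the compounds shown here, until now only two methylsulfonyl-bearing pyridinyl groups had been compared on the shared core at this place, on a nitrogen on an aromatic ring in a ring. Compound 4 extends the comparison to a ring of carbon only that also carries fluorine, and in this assay both new steps stay within the scatter: a 1.6-fold lower number from compound 3 to compound 4 (0.20 log units; within the scatter) and a 1.3-fold higher number from compound 2 to compound 4 (0.10 log units; within the scatter), so the ring nitrogen of either pyridinyl group is not required for a number in this range. Nothing available explains why these three groups read alike.

Going by these compounds, the exchange removes the ring nitrogen and adds the fluorine in one step, so their separate contributions remain open, and a plain 4-(methylsulfonyl)phenyl on the shared core would separate them. Also open, on these data alone, is how a nitrile or a carboxylic acid in place of the methylsulfonyl would read at this place.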